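A few compounds are considered here, and "the series" means these few. Any claim that something is new, unique, unknown or untested is made for them only; others in the source may bear on it.

Compound 1, `CCCCNC1=CC(=O)C=C(C(C)(C)C)C1=O`, and compound 2, `CCCCCCCCNC1=CC(=O)C=C(C(C)(C)C)C1=O`, share one core and differ only by butyl in place of hydrogen on a saturated chain carbon, four bonds along the chain from an amine nitrogen. In an ADME assay on HaCaT cells (Homo sapiens) for cytotoxicity, read by MTT assay, with a stated time of 72 h (a higher number here means a weaker inhibitor, a lower number a stronger inhibitor), compound 1 gives 11000 nM. Compound 2, carrying the longer chain, gives 30000 nM in this assay. The step of a 2.7-fold higher number from compound 1 to compound 2 (0.44 log units; beyond the scatter), so lengthening the chain left compound 2 somewhat less toxic to these cells.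

Compound 3, `CCCCNC1=CC(=O)C(C(C)(C)C)=CC1=O`, is built from the same atoms as compound 1, joined differently; how the two cores differ is not broken down here. In this assay compound 3 gives only a limit, > 100000 nM, rather than a number. That limit, (the limit of > 100000 nM in this assay, at which 1 of the 3 values shown sits), sits above every number recorded for the other compounds.

Compound 4, `CCCCCCCCNC1=CC(=O)C(C(C)(C)C)=CC1=O`, repeats the change seen from compound 1 to compound 2 on the core of compound 3: butyl in place of hydrogen on a saturated chain carbon, four bonds along the chain from an amine nitrogen. The place of the change is the same in both pairs. The expected step is a step that the limit leaves unreadable from compound 3 to compound 4, resting on the measured step of a 2.7-fold higher number from compound 1 to compound 2 (0.44 log units; beyond the scatter). Because compound 3 already gives only the limit > 100000 nM, compound 4 is estimated at 200000 nM, and most likely the assay will again report only a limit.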

Compound 4, half-maximal inhibitory concentration: > 100000 nM
Compound 4 ended at the assay's limit (the forecaster's own chance of this, stated with the estimate: 80%); the middle value is on the limit's open side.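

In this assay compound 4 gives > 100000 nM, which is a limit of the assay and not a number. Compound 3 also gives only a limit, so no step from compound 3 to compound 4 can be read: the limit of > 100000 nM in this assay, at which 2 of the 4 values shown sit.

The compounds shown leave open whether butyl in place of hydrogen changes the result on the core of compound 3 as it does on the core of compound 1.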